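The source may hold more compounds than are shown below. What is called first, only, known or untested is meant among the compounds shown, and "the series" means these compounds.

Among the compounds with values here, of the two numbers known so far, compound 2 `CN1CCN(c2nc3ccccc3n2CCOc2ccccc2)CC1` gives the smaller one, yet compound 1 `CCCN1CCCN(c2nc3ccccc3n2CCOCC)CC1` lies within the scatter of it. In a functional assay on ileum for inhibition of histamine H1 receptor (Cavia porcellus) (a higher number here means a weaker inhibitor, a lower number a stronger inhibitor), compound 2 gives 6.9 nM. In this assay compound 1 gives 8.4 nM. Compound 3 `CCOCCn1c(N2CCN(C)CC2)nc2ccccc21` differs from compound 2 by ethyl in place of phenyl on an oxygen on a saturated carbon. Within the data shown here, no measured pair shows this change on its own, so its effect is unknown; compound 1, which also carries an ethyl on such an oxygen, gives 8.4 nM. The step is therefore expected to be small, a 1.3-fold higher number from compound 2 to compound 3 (0.12 log units; within the scatter), with no direction beyond the scatter. Compound 3 is expected to give 9 nM, between 3 nM and 27 nM.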

Compound 3, half-maximal inhibitory concentration: 10 nM
Compound 3: the middle estimate sits 1.1-fold (0.05 log units) below what was measured; the measured number falls inside the stated range.
By their numbers in this assay, from the lowest: compounds 2, 1 and 3 (each within the scatter of the next).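

Within the data shown here, putting ethyl in place of phenyl on this oxygen gives a 1.4-fold higher number from compound 2 to compound 3 (0.16 log units; within the scatter) in this assay as the only change, the first measured view of this swap on its own. For this pair, then, the phenyl ring is not needed to keep the number within the scatter, and a group of just 2 carbons serves as well. Nothing measured here explains why the two groups match.
Still open, going by these compounds, is whether a longer chain such as butyl, or a cyclohexyl ring, on the same oxygen would also keep the number within the scatter.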